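Methoxy in Place of Methyl: One Expected Paw Edema Read-out

The source may hold more compounds than are shown below. What is called first, only, known or untested is meant among the compounds shown, and "the series" means these compounds.

Compound 1 `COc1ccc(-c2nn(-c3ccc(Cl)cc3)cc2C=O)cc1`: 63.1%
Compound 2 `COc1ccc(/N=C\c2cn(-c3ccc(Cl)cc3)nc2-c2ccc(C)cc2)cc1`: 62%

In a functional assay on the whole organism (strain Wistar albino) for inhibition, with Rattus norvegicus as the target, read by paw edema, with stated times of 1 h and 2 h, at a dose of 0.32 mmol/kg by the intraperitoneal route (on this read-out higher numbers stand for more inhibition at the one dose given (going by the name of the read-out) and lower numbers for less inhibition), compound 1 gives 63.1%. In this assay, among the compounds with values here, compound 2 gives 62%, a number that stands within the usual scatter of the one for compound 1, so the two compounds cannot be told apart on this read-out. Within the data shown here, no pair of measured compounds differs in a single place, so no measured step is at hand to guide the next one.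

Compound 3 `COc1ccc(/N=C\c2cn(-c3ccc(Cl)cc3)nc2-c2ccc(OC)cc2)cc1` has not yet been measured. Compared with compound 2 it differs as follows: methoxy in place of methyl on an aromatic carbon. Without a measured step for this kind of change, the expectation is a step in this assay of no change at the digits printed from compound 2 to compound 3 (within the scatter), one that stays within the scatter, with no direction claimed. Compound 3 is therefore estimated at 62%, with a range from 48% to 74%.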

Compound 3, a percentage reported as inhibition, in the whole organism at one dose (the size of the read-out at that dose, not a potency): 69.2%
The estimate for compound 3 lay 7.2 percentage points below the measured number; low and high end bracket the measured number.
By their numbers in this assay, from the lowest: compounds 2, 1 and 3 (each within the scatter of the next).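

In this assay, the change from 4-methylphenyl to 4-methoxyphenyl, on an aromatic carbon para to a large group, gives a number 7.2 percentage points higher from compound 2 to compound 3 (within the scatter), so this position accepts methoxy in place of methyl with a step that cannot be told apart from repeat scatter. The much larger exchange, a group of 10 heavy atoms in place of a group of 2 heavy atoms, gives a number 6.1 percentage points higher from compound 1 to compound 3 (within the scatter), so it too stays inside that scatter on this read-out. No measured evidence bears on either step.

Still open, from the compounds shown here alone, is whether another group at this position, such as an amine, a carboxylic acid or a longer chain, would move the read-out beyond the scatter. Going by these compounds, whether these compounds would separate at a different dose also remains unknown.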